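The source may hold more compounds than are shown below. What is called first, only, known or untested is meant among the compounds shown, and "the series" means these compounds.

In a functional assay on NRK-49F cells (Rattus norvegicus) for cytotoxicity, read by MTT assay, with a stated time of 24 h (on this read-out lower numbers stand for stronger inhibition and higher numbers for weaker inhibition), compound 1 (`C/C(=N\NC(=O)/C(C#N)=C/c1ccc(Br)cc1)c1c(O)c2ccc(O)cc2oc1=O`) gives 49600 nM, compound 2 (`C/C(=N\NC(=O)/C(C#N)=C/c1ccc(N(C)C)cc1)c1c(O)c2ccc(O)cc2oc1=O`) gives 53400 nM and compound 3 (`C/C(=N\NC(=O)/C(C#N)=C/c1cccc([N+](=O)[O-])c1)c1c(O)c2ccc(O)cc2oc1=O`) gives 46500 nM. Compound 3 therefore stands level with the other two, inside the scatter of each.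

The next step leads to compound 4 (`C/C(=N\NC(=O)/C(C#N)=C/c1ccccc1Cl)c1c(O)c2ccc(O)cc2oc1=O`), with 2-chlorophenyl in place of 3-nitrophenyl on a double-bonded chain carbon bound to a double-bonded chain carbon. Two measured steps change the group at this same place: a 1.1-fold lower number from compound 1 to compound 3 (0.03 log units; within the scatter) and a 1.1-fold lower number from compound 2 to compound 3 (0.06 log units; within the scatter). The remaining step, a 1.1-fold higher number from compound 1 to compound 2 (0.03 log units; within the scatter), is a change on an aromatic carbon and also stays inside the scatter. For the measured compounds named here, no measured compound carries the 2-chlorophenyl group, so the evidence for it is indirect.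

Given those steps to compound 3, no change beyond the scatter is expected in this assay, and no direction can be assigned. The expected step is a 1.0-fold higher number from compound 3 to compound 4 (0.01 log units; within the scatter). For compound 4 the estimated value is 48000 nM, with an expected range of 30000 nM to 75000 nM.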

Compound 4, half-maximal inhibitory concentration: 55900 nM
Compound 4: the middle estimate sits 1.2-fold (0.07 log units) below what was measured, within the range that was stated.
By their numbers in this assay, from the lowest: compounds 3, 1, 2 and 4 (each within the scatter of the next).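

In this assay, 2-chlorophenyl on a double-bonded chain carbon bound to a double-bonded chain carbon stays level with all three earlier aryl groups: a 1.2-fold higher number from compound 3 to compound 4 (0.08 log units; within the scatter), a 1.0-fold higher number from compound 2 to compound 4 (0.02 log units; within the scatter) and a 1.1-fold higher number from compound 1 to compound 4 (0.05 log units; within the scatter). The hydrogen-bond acceptors counted for the group go from 2 in 3-nitrophenyl to 0 in 2-chlorophenyl, and the step still remains within the scatter, so this place has now tolerated a chlorine-bearing ring as well as the bromo, dimethylamino and nitro rings. No measurement here bears on why the four compounds stay level.

As far as these compounds go, all four compounds carry a substituted phenyl ring at this place, so a carboxylic acid, an amine or a longer alkyl chain in its stead remains open. Also open, from the compounds shown here alone, is whether a change to the shared core would give a step beyond the scatter.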